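A few compounds are considered here, and "the series" means these few. Any claim that something is new, unique, unknown or untested is made for them only; others in the source may bear on it.

Measured so far in a functional assay on MCF7 cells (Homo sapiens) for antiproliferative activity, read by sulforhodamine B assay, with a stated time of 48 h; a higher number here means a weaker inhibitor, a lower number a stronger inhibitor:
compound 1, `CCc1ccccc1NS(=O)(=O)c1ccc(N2CCNC2=O)cc1`, gives 350 nM.
compound 2, `CCCCc1ccc(NS(=O)(=O)c2ccc(N3CCNC3=O)cc2)cc1`, gives 770 nM.
compound 3, `CC(C)(C)c1ccc(NS(=O)(=O)c2ccc(N3CCNC3=O)cc2)cc1`, gives only > 1000 nM, which is a limit of the assay and not a number.

Among the numbers shown, compound 1 has the lowest one; its nearest neighbour is compound 2, and that gap lies beyond the usual scatter. Compound 3 stands at the limit of > 1000 nM in this assay, at which 1 of the 3 values shown sits.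

For the measured compounds named here, the single measured step between compounds that differ in one place is an at least 1.2-fold higher number from compound 2 to compound 3 (0.11 log units; that floor lies within the scatter), tert-butyl in place of butyl on an aromatic carbon. Its floor lies within the scatter, so it says little about size, and it does not concern the part of the molecule that changes next.

Compound 4, `O=C1NCCN1c1ccc(S(=O)(=O)Nc2ccc(Cl)cc2)cc1`, differs from compound 1 by 4-chlorophenyl in place of 2-ethylphenyl on a sulfonamide nitrogen. Going by the values given here, no measured step covers this exchange. What can be said is that compound 2 and compound 3, each carrying a different group on the phenyl attached to the sulfonamide nitrogen, give higher numbers than compound 1, so some rise in the number is expected rather than a fall. Compound 4 is therefore estimated at 550 nM, with a range from 200 nM to 1500 nM. That estimate means a 1.6-fold higher number from compound 1 to compound 4 (0.20 log units; within the scatter).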

Compound 4, half-maximal inhibitory concentration: 170 nM
Compound 4: the middle estimate sits 3.2-fold (0.51 log units) above what was measured; the whole stated range lies above it.
By their numbers in this assay, from the lowest: compound 4; then compound 1; then compound 2. At a limit, above all of these: compound 3.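

In this assay, the exchange on the sulfonamide nitrogen gives a 2.1-fold lower number from compound 1 to compound 4 (0.31 log units; beyond the scatter), so compound 1 no longer holds the lowest number and 4-chlorophenyl is the better of these two groups at this position. Chloro in place of butyl on an aromatic carbon gives a 4.5-fold lower number from compound 2 to compound 4 (0.66 log units; beyond the scatter), which shows that the group carried by this phenyl can shift the number well beyond the scatter, in the direction opposite to the one the earlier compounds suggested. Chloro in place of tert-butyl gives an at least 5.8-fold lower number from compound 3 to compound 4 (0.76 log units; beyond the scatter), which is a floor and not a true size, since the starting value is a limit and not a number: the limit of > 1000 nM in this assay, at which 1 of the 4 values shown sits.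

The names 2-ethylphenyl and 4-chlorophenyl differ both in the group and in its place on the ring, so these compounds cannot tell which of the two accounts for the lower number, and they do not say why it falls. Going by these compounds, it also remains open how this phenyl would behave with a fluorine, a methoxy group, an amine or a carboxylic acid in place of the chlorine.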